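A few compounds are considered here, and "the series" means these few. Any claim that something is new, unique, unknown or untested is made for them only; others in the source may bear on it.

Measured compounds in a functional assay on SK-LU-1 cells (Homo sapiens) for cytotoxicity, read by sulforhodamine B assay, with a stated time of 48 h, tested at 50 uM; on this read-out lower numbers stand for less inhibition and higher numbers for more inhibition at the one concentration tested (going by the name of the read-out):
- compound 1 `FC(F)(F)c1ccc(Nc2nccc(-c3cnc4ccccc4c3)n2)cc1`: 35.4%
- compound 2 `Cc1ccc(Nc2nccc(-c3c(C)nc4ccccn34)n2)cc1`: 100%
- compound 3 `Cc1ccc(Nc2nccc(-c3cnc4ccccc4c3)n2)cc1`: 46.3%

Compound 2 gives the highest number of the three; compound 3 lies well below it, and compound 1 lies further below still, both gaps beyond the scatter. How the core of compound 2 differs from the core of compound 3 is not broken down here.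

Compound 3 and compound 1 share their core and differ in one place: trifluoromethyl in place of methyl on an aromatic carbon. In this assay the step of a number 10.9 percentage points lower from compound 3 to compound 1 (beyond the scatter) is beyond the scatter but modest.

Compound 4 `Cc1nc2ccccn2c1-c1ccnc(Nc2ccc(C(F)(F)F)cc2)n1` is not yet measured. It stands to compound 2 as compound 1 stands to compound 3: trifluoromethyl in place of methyl on an aromatic carbon. The place of the change is the same in both pairs, so this is the same change made on the other core.

Within the data shown here, for compound 4 in this assay a drop of roughly the same size as the precedent is expected, a number 12 percentage points lower from compound 2 to compound 4 (beyond the scatter), because the only precedent is a number 10.9 percentage points lower from compound 3 to compound 1 (beyond the scatter) on the core of compound 3. The expectation is uncertain because compound 2 gives 100%, the top of the read-out, so the starting number may hide a larger margin than it shows. Compound 4 is therefore estimated at 88%, between 65% and 100%.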

Compound 4, a percentage reported as inhibition, at one concentration (the size of the read-out at that concentration, not a potency): 100%
Compound 4: middle estimate off by 12 percentage points, on the low side, and the stated range covers the measured number.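

In this assay, trifluoromethyl in place of methyl on an aromatic carbon gives no change at the digits printed from compound 2 to compound 4 (within the scatter) on the core of compound 2. Set beside the same change on the core of compound 3, the two steps do not separate: the same change on two cores in this assay, a number 10.9 percentage points lower (beyond the scatter) from compound 3 to compound 1 and no change at the digits printed (within the scatter) from compound 2 to compound 4, 10.9 percentage points apart, within the scatter of two such steps

Among these compounds, the change therefore carries from one core to the other without a detectable difference in this read-out, but this rests on only two pairs and does not show that its size is the same on both cores: compound 2 gives 100% and compound 4 gives 100%, the top of the read-out at the one concentration tested, so a difference between these two compounds could stay hidden there.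

The compounds shown leave open how other groups at the same place, such as a methoxy, a chlorine or an amine, would behave on either core. They also leave open whether compound 2 and compound 4 would still match in a read-out at lower concentrations, where neither sits at the top, and so whether the step on the core of compound 2 is truly absent.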